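The source may hold more compounds than are shown below. What is called first, only, known or untested is meant among the compounds shown, and "the series" means these compounds.

Measured compounds:
Compound 1 `CCCN(CCC)c1cc(C)nc2c(-c3ncc(I)cc3C)c(C)nn12` gives 6.6 nM.
Compound 2 `CCCN(CCC)c1cc(C)nc2c(-c3ncccc3C)c(C)nn12` gives 110 nM.

Within the data shown here, in an assay on isolated protein for binding affinity to corticotropin-releasing factor receptor 1 (Homo sapiens) (on this read-out lower numbers stand for stronger inhibition and higher numbers for weaker inhibition), compound 2 stands with the higher of the two numbers; its nearest neighbour is compound 1, and the only step known, a 17-fold higher number from compound 1 to compound 2 (1.22 log units; beyond the scatter), shows how much a single change on the pyridine ring can move this read-out. Compound 3 `CCCN(CCC)c1cc(C)nc2c(-c3ncc(C)cc3N)c(C)nn12` is not yet measured. It differs from compound 2 in that (3-amino-5-methylpyridin-2-yl in place of 3-methylpyridin-2-yl on an aromatic carbon). Two things happen at once here: a methyl enters on the pyridine ring where compound 1 carries iodo, and an amino group takes the place of the methyl that compound 2 already carries on that ring. The step of a 17-fold higher number from compound 1 to compound 2 (1.22 log units; beyond the scatter) bears on the first part, since it shows that a substituent on that ring carbon is worth a large gain in this assay; nothing measured speaks to the second part. A partial recovery toward the number of compound 1 is therefore expected, and compound 3 is estimated at 25 nM (range 8 nM to 80 nM), which means an expected step of a 4.4-fold lower number from compound 2 to compound 3 (0.64 log units; beyond the scatter).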

Compound 3, inhibition constant: 40 nM
Compound 3: the middle estimate sits 1.6-fold (0.20 log units) below what was measured; measured number inside the range.
By their numbers in this assay, from the lowest: compound 1; then compound 3; then compound 2.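

In this assay the swap of 3-methylpyridin-2-yl for 3-amino-5-methylpyridin-2-yl gives a 2.8-fold lower number from compound 2 to compound 3 (0.44 log units; beyond the scatter) and so counts as a net gain, which shows that this place on the shared core can take a group with an amino substituent and still improve on compound 2. The same group does not reach the level of the 5-iodo-3-methylpyridin-2-yl group, with a 6.1-fold higher number from compound 1 to compound 3 (0.78 log units; beyond the scatter) as the remaining distance, so among these three compounds the iodo-bearing group keeps the lowest number and the new group recovers only part of what compound 2 lost. No independent data on these compounds explain either step.

Since the methyl and the amino group arrive together, the compounds shown leave open how much of the gain belongs to each, a question that the 3-aminopyridin-2-yl and 3,5-dimethylpyridin-2-yl groups would separate. Also open, as far as these compounds go, is whether the amino group adds to the iodo substituent, as in a 3-amino-5-iodopyridin-2-yl group, or whether a bromo or chloro substituent could stand in for the iodo.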